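The source may hold more compounds than are shown below. What is called first, only, known or untested is meant among the compounds shown, and "the series" means these compounds.

Measured so far in an in vivo functional assay on the whole organism for inhibition, with Rattus norvegicus as the target; a higher number here means that more compound is needed for the effect, a lower number that less compound is needed:
- Compound 1 `CCCCc1nc(C)c(CC(=O)O)c(=O)n1Cc1ccc(-c2ccccc2-c2nnn[nH]2)cc1`: 0.13 mg/kg
- Compound 2 `CCCCc1nc(C)c(CC(=O)N2CCCC2)c(=O)n1Cc1ccc(-c2ccccc2-c2nnn[nH]2)cc1`: 0.056 mg/kg
- Compound 3 `CCCCc1nc(C)c(CCC(=O)N2CCC[C@H]2C(=O)OC)c(=O)n1Cc1ccc(-c2ccccc2-c2nnn[nH]2)cc1`: 0.063 mg/kg

Compound 3 sits close to its nearest neighbour, with a gap of a 1.1-fold higher number from compound 2 to compound 3 (0.05 log units; within the scatter). Its gap to the remaining compound is a 2.1-fold lower number from compound 1 to compound 3 (0.31 log units; beyond the scatter).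

Compound 4 `CCCCc1nc(C)c(CCC(=O)N2CCCCC2)c(=O)n1Cc1ccc(-c2ccccc2-c2nnn[nH]2)cc1` differs from compound 3 at one place, on a carbonyl carbon: piperidin-1-yl in place of 2-(methoxycarbonyl)pyrrolidin-1-yl on a carbonyl carbon. Going by the values given here, no measured compound carries piperidin-1-yl, and no measured step makes this exact swap. The closest evidence is compound 3 against compound 2, where side chains with and without methoxycarbonyl on the pyrrolidine gave a 1.1-fold higher number from compound 2 to compound 3 (0.05 log units; within the scatter). Replacing hydroxy with pyrrolidin-1-yl gave a modest 2.3-fold lower number from compound 1 to compound 2 (0.37 log units; beyond the scatter).

No step beyond the scatter is therefore expected in this assay, and the estimated step is a 1.1-fold lower number from compound 3 to compound 4 (0.02 log units; within the scatter). For compound 4 the estimate is 0.06 mg/kg, with an expected range from 0.025 mg/kg to 0.15 mg/kg.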

Compound 4, dose for half-maximal effect: 0.164 mg/kg
Beside the measured number, compound 4's estimate is 2.7-fold (0.44 log units) below it; measured number above the stated range.
By their numbers in this assay, from the lowest: compounds 2 and 3 (each within the scatter of the next); then compounds 1 and 4 (each within the scatter of the next).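

In this assay, going by these compounds alone, the group on this carbonyl carbon turns out to matter: piperidin-1-yl in place of 2-(methoxycarbonyl)pyrrolidin-1-yl gives a 2.6-fold higher number from compound 3 to compound 4 (0.42 log units; beyond the scatter), a sensitivity the earlier compounds did not reveal. The piperidin-1-yl compound also shows a 2.9-fold higher number from compound 2 to compound 4 (0.47 log units; beyond the scatter), yet a 1.3-fold higher number from compound 1 to compound 4 (0.10 log units; within the scatter), so it shows no gain over the carboxy compound. No measurement here explains the loss.

On these data alone, compound 4 changes both ring size and the methoxycarbonyl group, so their separate contributions remain unknown. A piperidine carrying methoxycarbonyl, or a pyrrolidine carrying a free carboxylic acid, would help separate them.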